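Chloro for Methoxy: Predicting Compound 3 from Compound 2

The compounds below may be only part of what the source reports. "The series", "measured", "known", "first", "only" and "open" are said of these compounds alone.

Measured in a functional assay on Ehrlich cells (Mus musculus) for cytotoxicity, tested at 50 ug/mL; on this read-out lower numbers stand for a weaker effect and higher numbers for a stronger effect at the one concentration tested:
compound 1 `COc1cc(N2C(N)=C(C#N)C(c3ccc(OC)c4ccccc34)C3=C2CC(C)(C)CC3=O)cc(OC)c1OC`: 40%
compound 2 `COc1ccccc1C1C(C#N)=C(N)N(c2cc(OC)c(OC)c(OC)c2)C2=C1C(=O)CC(C)(C)C2`: 70%

Of the compounds shown here, two sharing one core have been tested in this assay. Compound 1 gives 40%, and compound 2 gives 70%. Compound 2 stands highest of the two numbers; its nearest neighbour is compound 1, and the step of a number 30 percentage points higher from compound 1 to compound 2 (beyond the scatter) came with 2-methoxyphenyl in place of 4-methoxynaphthalen-1-yl on a saturated ring carbon.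

Compound 3 `COc1cc(N2C(N)=C(C#N)C(c3ccccc3Cl)C3=C2CC(C)(C)CC3=O)cc(OC)c1OC` has not yet been measured. It differs from compound 2 in one place: chloro in place of methoxy on an aromatic carbon. Going by the values given here, no measured step bears on this change. Among the compounds with values here, the only step seen exchanged the whole group on the saturated ring carbon rather than one substituent on it, so it gives no guide to a chloro for methoxy exchange. The step is therefore expected to be a number 5 percentage points lower from compound 2 to compound 3 (within the scatter), staying within the scatter. The estimate for compound 3 is 65%, with a range from 40% to 90%.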

Compound 3, a percentage reported as activity, at one concentration (the size of the read-out at that concentration, not a potency): 20%
Beside the measured number, compound 3's estimate is 45 percentage points above it; the whole stated range lies above it.
By their numbers in this assay, from the lowest: compound 3; then compound 1; then compound 2.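

In this assay, the exchange of methoxy for chloro on an aromatic carbon ortho to a large group is far from neutral: it brings a number 50 percentage points lower from compound 2 to compound 3 (beyond the scatter). One substituent on this ring therefore moves the read-out more than the whole-group exchange did, and the choice of group also reverses the direction of the change from the 4-methoxynaphthalen-1-yl compound: 2-chlorophenyl brings a number 20 percentage points lower from compound 1 to compound 3 (beyond the scatter), whereas 2-methoxyphenyl brought a number 30 percentage points higher from compound 1 to compound 2 (beyond the scatter). Nothing available explains the size of this drop.

The compounds shown leave open whether the fall follows from the arrival of chloro or from the departure of methoxy. They also leave open where another group on this aromatic carbon, such as hydroxyl, an amine or a longer ether chain, would fall relative to compound 2 and compound 3.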